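A second chloro on the benzyl ring of compound 2

This account rests on a few compounds, and the source may have more. Where it says the series, first, only, none or still open, it means among the compounds named here.

Measured so far:
Compound 1, `O=C(NC(=S)Nc1ccc(Cl)c(-c2nc3ccccc3[nH]2)c1)c1ccc(OCc2ccc(Cl)c(Cl)c2)cc1`: 4930 nM
Compound 2, `Cc1ccc(NC(=O)NC(=O)c2ccc(OCc3cccc(Cl)c3)cc2)cc1-c1nc2ccccc2[nH]1`: 15400 nM

Within the data shown here, in a functional assay on HT-29 cells (Homo sapiens) for inhibition, read by MTT assay, with a stated time of 48 h (a higher number here means a weaker inhibitor, a lower number a stronger inhibitor), compound 2 gives the higher of the two numbers known, and compound 1 gives 4930 nM, a gap between the two compounds that lies beyond the scatter. The two compounds differ in several places at once, so their values can only be taken as they stand.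

Compound 3, `Cc1ccc(NC(=O)NC(=O)c2ccc(OCc3ccc(Cl)c(Cl)c3)cc2)cc1-c1nc2ccccc2[nH]1`, has not yet been measured in this assay. It carries chloro in place of hydrogen on an aromatic carbon, so that the (3-chlorobenzyl)oxy group of compound 2 becomes a (3,4-dichlorobenzyl)oxy group. Among the measured compounds shown here, no measured pair isolates this one change, and the step from compound 2 to compound 3 is therefore expected to be modest, with a lower number somewhat more likely than a higher one. Compound 3 is estimated at 9000 nM, within a range of 3500 nM to 22000 nM, which corresponds to an expected step of a 1.7-fold lower number from compound 2 to compound 3 (0.23 log units; within the scatter).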

Compound 3, half-maximal inhibitory concentration: 1030 nM
Beside the measured number, compound 3's estimate is 8.7-fold (0.94 log units) above it, and the stated range ends above it.
By their numbers in this assay, from the lowest: compound 3; then compound 1; then compound 2.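

In this assay, among these compounds, this is the first pair differing in one place, and adding a single chloro gives a 15-fold lower number from compound 2 to compound 3 (1.17 log units; beyond the scatter). The earlier compounds shown here differed in several places at once and could not single out any position, whereas this pair shows that the aromatic carbon ortho to a chloro group and para to a large group responds strongly to one added heavy atom. Nothing measured here explains the size of this step.

On these data alone, it remains open whether chloro is specifically needed at this carbon or whether a fluoro or a methoxy group would give a similar step. Also open, as far as these compounds go, is whether the step carries over to compound 1, which has the same (3,4-dichlorobenzyl)oxy group but no partner differing from it only at this position.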